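From 2-fluorophenyl to 4-bromophenyl on a shared core

The source may report more compounds than this note shows. Statements on the series, on what has been measured and on what is new or still open speak of the compounds shown alone.

Three measured compounds share one core and differ in the aryl group on the amine nitrogen: compound 1 `O=C1C(Nc2ccccc2)=CC(=O)c2c1nc1n2[C@H]2OC[C@@H](O)[C@H]2OC1` with an unsubstituted phenyl, compound 2 `O=C1C=C(Nc2ccccc2F)C(=O)c2c1nc1n2[C@H]2OC[C@@H](O)[C@H]2OC1` with 2-fluorophenyl, and compound 3 `O=C1C(Nc2ccc(C(F)(F)F)cc2)=CC(=O)c2c1nc1n2[C@H]2OC[C@@H](O)[C@H]2OC1` with a trifluoromethyl-bearing phenyl. In a functional assay on MGC-803 cells (Homo sapiens) for inhibition, read by sulforhodamine B assay (on this read-out lower numbers stand for stronger inhibition and higher numbers for weaker inhibition), compound 1 gives 1830 nM as its value, compound 2 gives 2080 nM and compound 3 gives 1860 nM on the same read-out. Compound 2 therefore stands level with the other two, as its gaps to both lie within the scatter.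

The next compound, compound 4 `O=C1C=C(Nc2ccc(Br)cc2)C(=O)c2c1nc1n2[C@H]2OC[C@@H](O)[C@H]2OC1`, has 4-bromophenyl in place of 2-fluorophenyl on an amine nitrogen. Within the data shown here, one measured step bears on this change: a 1.0-fold higher number from compound 1 to compound 3 (0.01 log units; within the scatter) when trifluoromethyl takes the place of hydrogen on an aromatic carbon. That step stays within the scatter, and the values of compound 1 and compound 2 also sit within the scatter of each other. Among the measured compounds shown here, no measured compound carries bromine, so the range is kept wide. The expected step is a 1.2-fold lower number from compound 2 to compound 4 (0.06 log units; within the scatter) and nothing beyond the scatter is expected. For compound 4 the estimated value is 1800 nM in a range from 950 nM to 3400 nM on this evidence.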

Compound 4, half-maximal inhibitory concentration: 1010 nM
Estimate against measurement, compound 4: 1.8-fold (0.25 log units) above; measured number inside the range.
By their numbers in this assay, from the lowest: compounds 4, 1, 3 and 2 (each within the scatter of the next, the first and the last beyond it).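

In this assay, replacing 2-fluorophenyl with 4-bromophenyl on the amine nitrogen gives a 2.1-fold lower number from compound 2 to compound 4 (0.31 log units; beyond the scatter), the first step among these compounds that lies beyond the scatter, though only modestly. The earlier step, a 1.0-fold higher number from compound 1 to compound 3 (0.01 log units; within the scatter), showed no visible change on exchanging hydrogen for trifluoromethyl, whereas this pair shows that the number can move with the aryl group on this nitrogen, even if compound 4 remains within the scatter of compound 1. No evidence is available here to explain this step or connect it to any property of either group.

The compounds shown leave open whether the step goes with the exchange of fluorine for bromine or with the different place of the halogen, as this single change alters both; 2-bromophenyl and 4-fluorophenyl on the same amine nitrogen would separate the two. Also open, as far as these compounds go, is how far the trend reaches beyond halogens and trifluoromethyl, for instance to a phenyl group carrying a carboxylic acid or an amine.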